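Swapping Methyl for Chloro in a Dopamine Transporter Series

The source may report more compounds than this note shows. Statements on the series, on what has been measured and on what is new or still open speak of the compounds shown alone.

Three related compounds share a common core. Compound 1 `CNCc1cnccc1Oc1ccc(Cl)cc1C` has no reported result in an assay on HEK293 cells for inhibition of sodium-dependent dopamine transporter (Homo sapiens); on this read-out higher numbers stand for weaker inhibition and lower numbers for stronger inhibition: for compound 1 the entry reads "not determined" (no result reported). For the measured compounds named here, compound 2 `Cc1cc(Cl)ccc1Oc1ccncc1CN(C)C` is the only compound with a number: in this assay compound 2 gives 3230 nM. No other value is shown, so compound 2 stands alone and cannot be placed above or below any other measured compound.

Compound 3 `CN(C)Cc1cnccc1Oc1ccc(Cl)cc1Cl` is not yet measured. It differs from compound 2 by a single change: chloro in place of methyl on an aromatic carbon. Going by the values given here, no pair of measured compounds shows what such an exchange does here, so the expectation rests only on the nature of the change itself: one heavy atom replaces one heavy atom, with no ring, no hydrogen-bond donor or acceptor, and no charge added or removed. The step is therefore expected to be small, a 1.3-fold lower number from compound 2 to compound 3 (0.11 log units; within the scatter), most likely a modest gain in inhibition and possibly nothing beyond the usual scatter. On that basis compound 3 is estimated to give about 2500 nM in this assay, with a plausible range from 1000 nM to 6000 nM.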

Compound 3, half-maximal inhibitory concentration: 2430 nM
Beside the measured number, compound 3's estimate is 1.0-fold (0.01 log units) above it; measured number inside the range.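

In this assay, for the compounds shown here, exchanging methyl for chloro gives a 1.3-fold lower number from compound 2 to compound 3 (0.12 log units; within the scatter), and this provides the first measured pair, showing that the two compounds cannot be told apart on this read-out. At this place, on an aromatic carbon ortho to a large group and meta to a chloro group, chloro can therefore stand in for methyl with no difference that rises above the ordinary spread of repeated measurements, at least with the rest of the molecule as it is in compound 2 and compound 3. The data shown offer no measurement that would explain this outcome.

On these data alone, whether a different group at this place, such as methoxy, trifluoromethyl or nitrile, or simply a hydrogen atom, would move the number beyond that spread remains open, so this single pair says little about how much the position matters overall. With no number for compound 1, which carries a methylamino group where compound 2 and compound 3 carry a dimethylamino group, the effect of that change on the amine also cannot be read.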